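The source may report more compounds than this note shows. Statements on the series, on what has been measured and on what is new or still open speak of the compounds shown alone.

In an ADME assay on MT4 cells (Homo sapiens) for cytotoxicity, read by MTT assay (a lower number here means that less compound is tolerated, a higher number that more compound is tolerated), compound 3 `Cc1ccccc1NC(=O)CSc1nncnc1-c1ccccc1Cl` gives 142000 nM. That matches compound 1 `Cc1cnc(NC(=O)CSc2nncnc2-c2ccccc2Cl)c(Br)c1` at 144000 nM and lies well apart from compound 2 `CC(=O)c1ccc(NC(=O)CSc2nncnc2-c2ccccc2Cl)c(Br)c1` at 34000 nM. Compound 4 `Cc1ccc(NC(=O)CSc2nncnc2-c2ccccc2Cl)c(Br)c1` is still unmeasured and differs from compound 3 in one group: 2-bromo-4-methylphenyl in place of 2-methylphenyl on an amide-type nitrogen, with 2-bromo-4-methylphenyl in place of 2-methylphenyl on an amide-type nitrogen. Within the data shown here, the one measured step that bears on this is a 1.0-fold lower number from compound 1 to compound 3 (0.01 log units; within the scatter), which also swaps the group on that nitrogen and loses a bromine-bearing group without a change beyond the scatter. Compound 2 also carries bromine and reads lower, but its other group differs too. No shift beyond the scatter is therefore expected in this assay, and the expected step is a 1.4-fold lower number from compound 3 to compound 4 (0.15 log units; within the scatter). The estimated value for compound 4 is 100000 nM, within a range from 40000 nM to 200000 nM.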

Compound 4, half-maximal cytotoxic concentration: 45000 nM
The estimate for compound 4 lay 2.2-fold (0.35 log units) above the measured number, within the range that was stated.
By their numbers in this assay, from the lowest: compounds 2 and 4 (each within the scatter of the next); then compounds 3 and 1 (each within the scatter of the next).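

Putting 2-bromo-4-methylphenyl in place of 2-methylphenyl on the amide-type nitrogen gives a 3.2-fold lower number from compound 3 to compound 4 (0.50 log units; beyond the scatter) in this assay, so this position can move the number, which the step from compound 1 to compound 3 did not reveal. The same group in place of 3-bromo-5-methylpyridin-2-yl gives a 3.2-fold lower number from compound 1 to compound 4 (0.51 log units; beyond the scatter) even though both groups carry bromine, so bromine alone does not set the number. Methyl in place of acetyl on an aromatic carbon gives a 1.3-fold higher number from compound 2 to compound 4 (0.12 log units; within the scatter) and leaves the number within the scatter.

Going by these compounds, how an amine or a carboxylic acid on this ring would read remains open. No measured evidence explains these steps.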